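Removing the Aryl Ether Methyl from Compound 2

A few compounds are considered here, and "the series" means these few. Any claim that something is new, unique, unknown or untested is made for them only; others in the source may bear on it.

The compounds are compared in a functional assay on CAKI-1 cells (Homo sapiens) for inhibition, read by sulforhodamine B assay, with a stated time of 48 h; a higher number here means a weaker inhibitor of growth, a lower number a stronger inhibitor of growth. Going by the values given here, compound 2 `COc1cc(-c2nn(-c3cccc(NC(=O)Nc4ccc(Cl)c(C(F)(F)F)c4)c3)cc2-c2ccncc2)ccc1Cl` gives 4720 nM in this assay, the only true number measured so far. Compound 1 `O=C(Nc1cccc(-n2cc(-c3ccncc3)c(-c3ccc(Cl)c(O)c3)n2)c1)Nc1cccc(C(F)(F)F)c1` reaches only a limit of > 32500 nM in this assay. That limit, (the limit of > 32500 nM in this assay, at which 1 of the 2 values shown sits), is where one of the two results sits. Compound 3 `O=C(Nc1cccc(-n2cc(-c3ccncc3)c(-c3ccc(Cl)c(O)c3)n2)c1)Nc1ccc(Cl)c(C(F)(F)F)c1` has not been measured. It differs from compound 2 by hydrogen in place of methyl on an oxygen on an aromatic ring, so that 4-chloro-3-methoxyphenyl becomes 4-chloro-3-hydroxyphenyl. Among the compounds with values here, no measured pair shows this change directly. Compound 1 carries the same hydroxy group and sits at the limit (the limit of > 32500 nM in this assay, at which 1 of the 2 values shown sits), so the change is expected to weaken growth inhibition beyond the scatter, by a 3.2-fold higher number from compound 2 to compound 3 (0.50 log units; beyond the scatter). Compound 3 is therefore estimated at 15000 nM, within 5000 nM to 40000 nM, with a fair chance that only a limit is reported.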

Compound 3, concentration for total growth inhibition: 2630 nM
Beside the measured number, compound 3's estimate is 5.7-fold (0.76 log units) above it, outside the stated range (below it).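

In this assay, hydroxy in place of methoxy gives a 1.8-fold lower number from compound 2 to compound 3 (0.25 log units; within the scatter), so removing the methyl on an oxygen on an aromatic ring leaves no change that stands out from the scatter. The free hydroxy group therefore does not by itself go with weak growth inhibition, as compound 1 had suggested: with the hydroxy kept, chloro in place of hydrogen on an aromatic carbon gives an at least 12-fold lower number from compound 1 to compound 3 (1.09 log units; beyond the scatter). The figure for compound 1 is a limit of the assay and not a number, so the full size of that step stays unknown: the limit of > 32500 nM in this assay, at which 1 of the 3 values shown sits.

The compounds shown leave open whether the oxygen would carry an ethyl group or a longer chain, or whether an amine could stand in place of the hydroxy. They also leave open whether the chloro step would be as large with methoxy in place of hydroxy.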